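Fluoro Addition on the Anilide Ring of Compound 2

The source may report more compounds than this note shows. Statements on the series, on what has been measured and on what is new or still open speak of the compounds shown alone.

Of the compounds shown here, three sharing one core have been measured in a functional assay on HT-29 cells (Homo sapiens) for antiproliferative activity, read by MTT assay, with a stated time of 72 h; on this read-out higher numbers stand for weaker inhibition and lower numbers for stronger inhibition. Compound 1 `O=C(Nc1ccc(Oc2ccnc3[nH]ccc23)c(F)c1)c1cc2cccnc2n(-c2ccccc2)c1=O` gives 160 nM. Compound 2 `Cn1ccc2c(Oc3ccc(NC(=O)c4cc5cccnc5n(-c5ccccc5)c4=O)cc3)ccnc21` gives 620 nM, which places it second highest of the three numbers. Going by the values given here, compound 3 `COc1ccc(-n2c(=O)c(C(=O)Nc3ccc(Oc4ccnc5c4ccn5C)cc3)cc3cccnc32)cc1` gives 2050 nM, and the single clean step, a 3.3-fold higher number from compound 2 to compound 3 (0.52 log units; beyond the scatter), comes from a methoxy in place of hydrogen on an aromatic carbon of the pendant phenyl ring.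

Compound 4 `Cn1ccc2c(Oc3ccc(NC(=O)c4cc5cccnc5n(-c5ccccc5)c4=O)cc3F)ccnc21` differs from compound 2 by fluoro in place of hydrogen on an aromatic carbon. Among the compounds with values here, no measured step matches this change exactly. The step from compound 2 to compound 3 concerns a different ring and so bears only indirectly on it. Compound 1 carries the same fluoro, but it also differs from compound 2 at the bicyclic core, so its value can only be compared, not taken as a step: compound 1 at 160 nM sits beneath compound 2 at 620 nM. On that comparison alone, compound 4 is expected to show a lower number, with the step from compound 2 to compound 4 estimated at a 1.9-fold lower number from compound 2 to compound 4 (0.29 log units; within the scatter). Compound 4 is therefore estimated at 320 nM, within a range of 120 nM to 850 nM.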

Compound 4, half-maximal inhibitory concentration: 510 nM
Compound 4: the middle estimate sits 1.6-fold (0.20 log units) below what was measured; low and high end bracket the measured number.
By their numbers in this assay, from the lowest: compound 1; then compounds 4 and 2 (each within the scatter of the next); then compound 3.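

In this assay, fluoro in place of hydrogen on an aromatic carbon, ortho to a large group and meta to a large group, gives a 1.2-fold lower number from compound 2 to compound 4 (0.08 log units; within the scatter), so at this position the change separates compound 4 from compound 2 by no more than repeated measurements would. Going by these compounds alone, the pair of compound 1 and compound 4 carries the fluoro on both sides and now isolates a single change that the earlier compounds could not: methyl in place of hydrogen on an aromatic nitrogen gives a 3.2-fold higher number from compound 1 to compound 4 (0.50 log units; beyond the scatter), a step beyond the scatter and clearly larger than the fluoro step. Nothing given here accounts for either step.

The compounds shown leave open whether chloro, an amine or a longer chain at this same aromatic carbon would give a step beyond the scatter, since fluoro is the only group read there. They also leave open whether the fluoro step would stay as small with the methoxy on the pendant phenyl ring of compound 3, or whether the methyl step would stay the same size with hydrogen in place of the fluoro.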